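The source may report more compounds than this note shows. Statements on the series, on what has been measured and on what is new or still open speak of the compounds shown alone.

Measured so far in a functional assay, read by spectrophotometry, with a stated time of 15 min, tested at 40 ug/mL; a lower number here means a weaker effect, a higher number a stronger effect of the compound at the concentration tested: compound 1 `COC(=O)c1cc(-c2csc(N/N=C/c3ccc(Cl)cc3Cl)n2)ccc1OCc1ccccc1` gives 63.5%; compound 2 `Clc1ccc(/C=N/Nc2nc(-c3ccccc3)cs2)c(Cl)c1` gives 78.9%; compound 3 `COC(=O)c1cc(-c2csc(N/N=C/c3cccs3)n2)ccc1OCc1ccccc1` gives 82.8%.

Compound 2 stands second highest of the three numbers in this assay. Its nearest neighbour is compound 3, whose number is higher by an amount within the scatter, so the two cannot be told apart; compound 1 lies furthest away, with a number lower than compound 2 by an amount beyond the scatter. Compound 1 and compound 2 differ in more than one place, so the gap between them is not tied to any single change.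

Compound 4 `COc1ccc(-c2csc(N/N=C/c3ccc(Cl)cc3Cl)n2)cc1` has not yet been measured in this assay. It differs from compound 2 in one place: methoxy in place of hydrogen on an aromatic carbon.

Within the data shown here, the only measured step, a number 19.3 percentage points higher from compound 1 to compound 3 (beyond the scatter), concerns the group on the carbon with a double bond to nitrogen, not the six-membered ring where the methoxy enters, so it does not bear on this change. Among the measured compounds shown here, no measured pair shows what a methoxy in this position does. With nothing to point in either direction, the step of a number 2.9 percentage points lower from compound 2 to compound 4 (within the scatter) is expected to fall within the scatter.

Compound 4 is therefore estimated at 76%, with a range from 60% to 89%.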

Compound 4, a percentage reported as inhibition, at one concentration (the size of the read-out at that concentration, not a potency): 79.7%
Compound 4: middle estimate off by 3.7 percentage points, on the low side; low and high end bracket the measured number.
By their numbers in this assay, from the lowest: compound 1; then compounds 2, 4 and 3 (each within the scatter of the next).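

In this assay, among these compounds, the change from phenyl to 4-methoxyphenyl gives a number 0.8 percentage points higher from compound 2 to compound 4 (within the scatter), the first measured reading for this position, which none of the earlier compounds could supply. A methoxy on the aromatic carbon para to a large group therefore leaves the read-out indistinguishable from that of the parent with hydrogen, at least in this pair, where both compounds carry the 2,4-dichlorophenyl group. Nothing measured on these compounds offers an explanation for this level result.

This single pair leaves open whether the position is equally undemanding towards other groups, such as an amine, a carboxylic acid or a longer chain like butoxy, and whether a methoxy elsewhere on the same ring would read the same. It also leaves open whether the methoxy would stay as level with thiophen-2-yl in place of 2,4-dichlorophenyl, since the compounds shown include no pair that tests this change with that group present.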